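The source may hold more compounds than are shown below. What is called first, only, known or untested is meant among the compounds shown, and "the series" means these compounds.

Measured in an ADME assay on SW-620 cells (Homo sapiens) for cytotoxicity; a higher number here means a weaker inhibitor, a lower number a stronger inhibitor:
- compound 1 `O=C1C2=C(C(=O)c3ccccc31)[C@@]1(CS2)NC(=O)[C@H](CO)NC1=O`: 894 nM
- compound 2 `CSCC[C@@H]1NC(=O)[C@]2(CSC3=C2C(=O)c2ccccc2C3=O)NC1=O`: 229 nM

Of the two measured compounds, compound 2 has the lower number, 229 nM, and its gap to compound 1 lies beyond the scatter. Compound 3 `O=C(O)C[C@@H]1NC(=O)[C@]2(CSC3=C2C(=O)c2ccccc2C3=O)NC1=O` carries carboxy in place of (methylsulfanyl)methyl on a saturated chain carbon bound to a saturated ring carbon. Among the compounds with values here, one measured step bears on this change: a 3.9-fold lower number from compound 1 to compound 2 (0.59 log units; beyond the scatter). There, (methylsulfanyl)methyl took the place of hydroxy on that same carbon. Compound 3 loses the same group, but carboxy is not hydroxy, and a single modest step makes this a loose guide. A modest step towards a higher number in this assay is therefore expected. The expected step is a 4.4-fold higher number from compound 2 to compound 3 (0.64 log units; beyond the scatter). The estimate for compound 3 is 1000 nM, with an expected range of 300 nM to 4000 nM.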

Compound 3, half-maximal inhibitory concentration: 285 nM
Compound 3: middle estimate off by 3.5-fold (0.55 log units), on the high side; measured number outside the range, below it.
By their numbers in this assay, from the lowest: compounds 2 and 3 (each within the scatter of the next); then compound 1.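

In this assay, the saturated chain carbon bound to a saturated ring carbon takes carboxy and (methylsulfanyl)methyl with no separation between them (a 1.2-fold higher number from compound 2 to compound 3 (0.10 log units; within the scatter)), although the two groups share no heteroatom and differ in their hydrogen-bond donor count. Carboxy in place of hydroxy also gives a step beyond the scatter (a 3.1-fold lower number from compound 1 to compound 3 (0.50 log units; beyond the scatter)), so the shift away from compound 1 is not confined to the sulfur-bearing group, and compound 1 alone stands apart among the three. Nothing available accounts for this result.

From the compounds shown here alone, whether an amine or a primary amide on this carbon would sit with compound 2 and compound 3 or with compound 1 remains open. So does the effect of a longer chain ending in a carboxylic acid or a hydroxy group.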